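Trimming the ring amine substituent from neopentyl to isopropyl

This account rests on a few compounds, and the source may have more. Where it says the series, first, only, none or still open, it means among the compounds named here.

The series shares a core carrying a urea-linked chloro- or iodophenyl group and a primary amide, with different substituents on the amine nitrogen of the saturated six-membered ring. Compound 1 `CC(C)(C)CN1CCc2c(sc(NC(=O)Nc3ccc(Cl)cc3)c2C(N)=O)C1` carries a neopentyl group there; in a functional assay (strain AB) with Danio rerio as the target, read by microscopy, with a stated time of 1 h (on this read-out higher numbers stand for an effect only at larger amounts of compound and lower numbers for an effect already at smaller amounts), compound 1 gives 5560 nM. This is the highest number among the three measured compounds. Compound 3 `CCN1CCc2c(sc(NC(=O)Nc3ccc(I)cc3)c2C(N)=O)C1`, which has an ethyl group on that nitrogen and an iodine instead of the chlorine on the phenyl ring, gives 1620 nM in this assay, a gap to compound 1 that lies beyond the scatter. Compound 2 `NC(=O)c1c(NC(=O)Nc2ccc(Cl)cc2)sc2c1CCN(CCCNC(=O)CCc1cccnc1)C2`, whose ring nitrogen bears a longer chain ending in a pyridine-containing amide, gives 470 nM, the lowest number of the set and again well separated from compound 1.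

Compound 4 `CC(C)N1CCc2c(sc(NC(=O)Nc3ccc(Cl)cc3)c2C(N)=O)C1` differs from compound 1 in one place: isopropyl in place of neopentyl on an amine nitrogen in a ring. Among the compounds with values here, with no directly comparable pair measured, the step from compound 1 to compound 4 can only be guessed from the trend that a smaller nitrogen substituent, as in compound 3, accompanied a lower number than the neopentyl of compound 1. The author expects a modest decrease, a 2.0-fold lower number from compound 1 to compound 4 (0.30 log units; within the scatter), though compound 3 also carries a different halogen, so the attribution is uncertain. Compound 4 is estimated at 2800 nM, with a likely range from 1000 nM to 7500 nM.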

Compound 4, half-maximal effective concentration: 1490 nM
For compound 4 the middle estimate is 1.9-fold (0.27 log units) above the measured one; the measured number falls inside the stated range.
By their numbers in this assay, from the lowest: compound 2; then compounds 4 and 3 (each within the scatter of the next); then compound 1.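

Compound 4 supplies the first comparison in this series that isolates the amine nitrogen in the ring, as the earlier compounds offered no listed step between compounds differing in one place. In this assay, isopropyl in place of neopentyl gives a 3.7-fold lower number from compound 1 to compound 4 (0.57 log units; beyond the scatter), showing that this change alone, with the rest of the structure held constant, moves the read-out beyond the usual scatter. No measurement shown here accounts for the size of this step, so the result records the change without explaining it.

The compounds shown leave open whether the number continues to fall with a methyl group or a hydrogen on this nitrogen, and whether a cyclopropyl or tert-butyl group would give a number closer to that of isopropyl or neopentyl. They also leave open how a chain on this nitrogen ending in a simple amine or a carboxylic acid would read in this assay.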